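The source may hold more compounds than are shown below. What is called first, only, known or untested is meant among the compounds shown, and "the series" means these compounds.

Measured so far:
- compound 1, `COc1cc(Cl)cc(-c2nn(-c3cccc(NC(=O)Nc4cccc(C(F)(F)F)c4)c3)cc2-c2ccncc2)c1`: 16.1%
- compound 2, `COc1cc(Cl)cc(-c2nn(-c3cccc(NC(=O)Nc4ccc(Cl)c(C(F)(F)F)c4)c3)cc2-c2ccncc2)c1`: 28.1%
- compound 3, `COc1cc(Cl)cc(-c2nn(-c3cccc(NC(=O)c4cc(C(F)(F)F)cc(C(F)(F)F)c4)c3)cc2-c2ccncc2)c1`: 86.4%

These three compounds share one core and were tested in a functional assay on SNB-19 cells (Homo sapiens) for inhibition, read by sulforhodamine B assay, with a stated time of 48 h, tested at 10 uM; on this read-out lower numbers stand for a stronger effect and higher numbers for a weaker effect at the one concentration tested. Compound 2 stands second highest of the three numbers: compound 1 lies a little lower, and the step of a number 12 percentage points higher from compound 1 to compound 2 (beyond the scatter) is modest, while compound 3 lies far higher, meaning a much weaker effect.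

Compound 4, `COc1cc(Cl)cc(-c2nn(-c3cccc(NC(=O)c4ccc(Cl)c(Cl)c4)c3)cc2-c2ccncc2)c1`, has not been measured. It differs from compound 2 in one place: 3,4-dichlorophenyl in place of (4-chloro-3-(trifluoromethyl)phenyl)amino on a carbonyl carbon. Among the measured compounds shown here, no measured step matches this change exactly. The step from compound 1 to compound 2 concerns only a chloro for a hydrogen and says little here. More telling is compound 3, which, like compound 4, carries an aromatic ring directly on its carbonyl carbon with no amino group. In this assay compound 3 gives 86.4%. Compound 2 gives 28.1%. On that basis compound 4 is expected to move upward by a large step, a number 41.9 percentage points higher from compound 2 to compound 4 (beyond the scatter), towards a weaker effect. The estimate for compound 4 is 70%, with a range from 40% to 95%.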

Compound 4, a percentage reported as activity, at one concentration (the size of the read-out at that concentration, not a potency): 71.6%
Compound 4: the middle estimate sits 1.6 percentage points below what was measured, and the stated range covers the measured number.
By their numbers in this assay, from the lowest: compound 1; then compound 2; then compound 4; then compound 3.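

In this assay, putting 3,4-dichlorophenyl on the carbonyl carbon in place of (4-chloro-3-(trifluoromethyl)phenyl)amino gives a number 43.5 percentage points higher from compound 2 to compound 4 (beyond the scatter), and putting it in place of (3-(trifluoromethyl)phenyl)amino gives a number 55.5 percentage points higher from compound 1 to compound 4 (beyond the scatter), so the effect at the one concentration tested weakens greatly in both cases. Compound 4 carries no trifluoromethyl, yet it lies high with compound 3, so among these four compounds the two with an aromatic ring directly on the carbonyl carbon give the higher numbers, and none goes against this. No measurement shown here explains the rise.

The change removes the amino link and also swaps trifluoromethyl for chloro, and these two parts remain unseparated: (3,4-dichlorophenyl)amino on the same carbonyl carbon would tell them apart. Going by these compounds, how a non-aromatic group there, such as morpholine, would read also remains open.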